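A few compounds are considered here, and "the series" means these few. Any claim that something is new, unique, unknown or untested is made for them only; others in the source may bear on it.

Compound 1 `O=C(CCCCCCc1ccccc1)c1nnc(-c2ccco2)s1` and compound 2 `O=C(CCCCCCc1ccccc1)c1nnc(-c2cccs2)s1` share one core, while compound 3 `O=C(CCCCCCc1ccccc1)c1nc(-c2ccco2)no1` and the unmeasured compound 4 `O=C(CCCCCCc1ccccc1)c1nc(-c2cccs2)no1` share another; how the two cores differ is not broken down here. In an assay on HEK-293T cells for inhibition of diacylglycerol lipase-alpha (Homo sapiens), read by colorimetric assay (on this read-out higher numbers stand for weaker inhibition and lower numbers for stronger inhibition), compound 1 gives only a limit, > 10000 nM. Compound 2 likewise returns a limit in this assay, > 10000 nM. In this assay compound 3 gives 933 nM. The change thiophen-2-yl in place of furan-2-yl on an aromatic carbon yields a step that the two limits leave unreadable from compound 1 to compound 2 because the limit of > 10000 nM in this assay, at which 2 of the 3 values shown sit, holds both values. The change thiophen-2-yl in place of furan-2-yl on an aromatic carbon is the same kind of change, though its place differs: in compound 1 the carbon is next to the ring nitrogen and next to the ring sulfur, whereas in compound 3 it lies between two ring nitrogen atoms, two ring bonds from the ring oxygen. Compound 4 is expected to give 1200 nM in this assay, between 400 nM and 4000 nM. That estimate means a step of a 1.3-fold higher number from compound 3 to compound 4 (0.11 log units; within the scatter), resting on compound 3 alone because a step that the two limits leave unreadable from compound 1 to compound 2 offers no readable size.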

Compound 4, half-maximal inhibitory concentration: 1950 nM
Compound 4: the middle estimate sits 1.6-fold (0.21 log units) below what was measured; measured number inside the range.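

In this assay, thiophen-2-yl in place of furan-2-yl on the core of compound 3 gives a 2.1-fold higher number from compound 3 to compound 4 (0.32 log units; beyond the scatter). On the core of compound 1 the same change cannot be read, because compound 1 and compound 2 both give only a limit of the assay: the limit of > 10000 nM in this assay, at which 2 of the 4 values shown sit. The change therefore has a readable size on one core only, and the compounds do not show whether that size or its direction carries over to the other core.

Across these compounds, only the core and the furan-2-yl or thiophen-2-yl group vary, while the chain stays the same. As far as these compounds go, what an amine in place of those groups, or a shorter chain, would do remains open.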